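Trading one hydroxy for hydrogen on a saturated chain

A few compounds are considered here, and "the series" means these few. Any claim that something is new, unique, unknown or untested is made for them only; others in the source may bear on it.

In a functional assay on P388 cells (Mus musculus) for cytotoxicity (a higher number here means a weaker inhibitor, a lower number a stronger inhibitor), compound 1 `C=C/C=C\[C@H](C)[C@H](OC(N)=O)[C@@H](C)[C@H](O)[C@@H](C)C/C(C)=C\[C@H](C)[C@H]1OC(=O)C=C[C@@H]1C` gives 3690 nM while compound 2 `CCCC[C@H](C)[C@H](OC(N)=O)[C@@H](C)[C@H](O)[C@@H](C)C/C(C)=C\[C@H](C)[C@@H](O)[C@@H](C)CC[C@@H](O)C[C@@H]1OC(=O)[C@H](C)[C@@H](O)[C@H]1C` gives 33.8 nM and so holds the lower of the two numbers measured, with a gap beyond the usual scatter. Compound 3 `C=C/C=C\[C@H](C)[C@H](OC(N)=O)[C@@H](C)[C@H](OC(C)=O)[C@@H](C)C/C(C)=C\[C@H](C)[C@@H](O)[C@@H](C)/C=C\[C@@H](O)C[C@@H]1OC(=O)C(C)=C[C@H]1C` yields no number, only a limit of the assay (> 8100 nM).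

Compound 4 `CCCC[C@H](C)[C@H](OC(N)=O)[C@@H](C)[C@H](O)[C@@H](C)C/C(C)=C\[C@H](C)[C@@H](O)[C@@H](C)CCCC[C@@H]1OC(=O)[C@H](C)[C@@H](O)[C@H]1C` departs from compound 2 in one place, with hydrogen in place of hydroxy on a saturated chain carbon bound to two saturated chain carbons. The rest of the structure stays the same. For the measured compounds named here, no measured pair isolates this change, since compound 1 and compound 3 each differ from compound 2 in several places, so the expectation rests on limited ground. Compound 2 at 33.8 nM is the reference point, and a single hydroxy is a small edit next to the differences that separate it from compound 1 at 3690 nM in this assay. A moderate move towards a higher number is therefore expected, well short of that gap. The expected step of a 3.6-fold higher number from compound 2 to compound 4 (0.55 log units; beyond the scatter) reflects this view. Compound 4 is estimated to give 120 nM in this assay (expected range 30 nM to 600 nM).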

Compound 4, half-maximal inhibitory concentration: 309 nM
Compound 4: middle estimate off by 2.6-fold (0.41 log units), on the low side; the range from low to high includes it.
By their numbers in this assay, from the lowest: compound 2; then compound 4; then compound 1. At a limit, above all of these: compound 3.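

For the compounds shown here, the single change gives a 9.1-fold higher number from compound 2 to compound 4 (0.96 log units; beyond the scatter) in this assay, which is the first measure of what this hydroxy contributes on its own. Compound 1 and compound 3 each differ from compound 2 in several places, so neither could separate the contribution of this saturated chain carbon from that of the other differences. The pair now shows that the hydroxy on a saturated chain carbon bound to two saturated chain carbons matters in this assay, although replacing it with hydrogen does not abolish the activity, as compound 4 still gives 309 nM.

The compounds shown offer no measurement that explains why the number rises with this change. As far as these compounds go, it remains open whether a methoxy group, a fluorine atom or an amine on the same carbon would give a value nearer to that of compound 2 or compound 4, and whether the hydroxy with the opposite configuration at that carbon would match compound 2.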